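A Third Methoxy Joins the Benzoyl Ring

A few compounds are considered here, and "the series" means these few. Any claim that something is new, unique, unknown or untested is made for them only; others in the source may bear on it.

Of the compounds shown here, three built on a shared core have been measured in a functional assay on HepG2 cells (Homo sapiens) for inhibition, read by MTT assay, with a stated time of 24 h; on this read-out higher numbers stand for weaker inhibition of growth and lower numbers for stronger inhibition of growth. Compound 1 `COc1ccccc1C(=O)n1c(-c2cn(C)c3ccccc23)nc2ccccc21` gives 31800 nM in this assay. Compound 2 `COc1ccc2c(c1)c(-c1nc3ccccc3n1C(=O)c1ccccc1OC)cn2C` gives 23600 nM. Compound 3 `COc1ccc(C(=O)n2c(-c3cn(C)c4ccc(Br)cc34)nc3ccccc32)cc1OC` gives 9700 nM, the lowest of the three numbers, and its gaps to compound 1 and to compound 2 both lie beyond the scatter, so it is the strongest inhibitor of growth measured so far.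

From compound 1 to compound 2 the change is methoxy in place of hydrogen on an aromatic carbon, and it brought a 1.3-fold lower number from compound 1 to compound 2 (0.13 log units; within the scatter). How the core of compound 3 differs from that of compound 1 is not broken down here.

Compound 4 `COc1cc(C(=O)n2c(-c3cn(C)c4ccc(Br)cc34)nc3ccccc32)cc(OC)c1OC` is not yet measured. It differs from compound 3 by methoxy in place of hydrogen on an aromatic carbon. Within the data shown here, this is the same kind of change as the one from compound 1 to compound 2, but not the same: there the new methoxy sat on a ring that is part of a fused system, meta and para to a fused ring; here it sits on a ring of carbon only, ortho to a methoxy group, meta to a methoxy group and meta to a large group.

He expects a 1.3-fold lower number from compound 3 to compound 4 (0.11 log units; within the scatter) for compound 4, resting on the earlier methoxy addition, which gave only a 1.3-fold lower number from compound 1 to compound 2 (0.13 log units; within the scatter). Compound 4 is thus estimated at 7500 nM, likely between 3000 nM and 20000 nM.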

Compound 4, concentration for 50% growth inhibition: 8200 nM
Beside the measured number, compound 4's estimate is 1.1-fold (0.04 log units) below it; the measured number falls inside the stated range.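

In this assay, methoxy in place of hydrogen on an aromatic carbon gave a 1.2-fold lower number from compound 3 to compound 4 (0.07 log units; within the scatter), so on this core too the step is no larger than repeated measurements would produce on their own. Set beside the earlier methoxy addition, the new step shows that the change behaves alike on the two cores, with no difference between them that the data can resolve: the same change on two cores in this assay, a 1.3-fold lower number (0.13 log units; within the scatter) from compound 1 to compound 2 and a 1.2-fold lower number (0.07 log units; within the scatter) from compound 3 to compound 4, 1.1-fold (0.06 log units) apart, within the scatter of two such steps This agreement is one of two steps that each stay within the scatter, so it does not show that methoxy truly strengthens inhibition of growth on either core, and it says nothing about how the change would behave on any core beyond these two, or at any other place on these rings.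

The compounds shown leave open whether a different group at the place taken by the new methoxy in compound 4, such as a hydroxy group, an amine, a carboxylic acid or a longer chain like butoxy, would move the number beyond the scatter. They also leave open whether any such group would act alike on both cores, as the methoxy addition does here.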